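A pyridin-4-yl group replaces ethoxy

A few compounds are considered here, and "the series" means these few. Any claim that something is new, unique, unknown or untested is made for them only; others in the source may bear on it.

Compound 2 (`CCO[C@H]1C[C@@H](c2coc3ccccc3c2=O)N(c2ccccc2)O1`) gives > 60000 nM in a functional assay on A549 cells (Homo sapiens) for inhibition, read by sulforhodamine B assay, with a stated time of 48 h (a lower number here means a stronger inhibitor, a higher number a weaker inhibitor), as a limit and not a number. Compound 1 (`COC(=O)[C@H]1C[C@@H](c2coc3ccccc3c2=O)N(c2ccccc2)O1`) gives > 60000 nM as a limit too. Compound 3 (`CCO[C@H]1C[C@@H](c2coc3ccc(C)cc3c2=O)N(c2ccccc2)O1`) gives 20700 nM as a measured number. Compound 2 therefore stands at the limit of > 60000 nM in this assay, at which 2 of the 3 values shown sit, with no number of its own.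

Compound 4 (`O=c1c([C@@H]2C[C@H](c3ccncc3)ON2c2ccccc2)coc2ccccc12`) has pyridin-4-yl in place of ethoxy on a saturated ring carbon next to the ring oxygen (pyridin-4-yl in place of ethoxy on a saturated ring carbon). At that carbon the data hold only a step that the two limits leave unreadable from compound 1 to compound 2 and so offer no size to carry over. Among the measured compounds shown here, the one readable step is an at least 2.8-fold lower number from compound 2 to compound 3 (0.46 log units; beyond the scatter) for methyl in place of hydrogen on an aromatic carbon. For the measured compounds named here, that is a different change, and it shows only that the core can reach a number in this assay at all.

A modest shift to a lower number is therefore expected, with a fair chance that compound 4 stays at the limit. The expected move is an at least 1.3-fold lower number from compound 2 to compound 4 (0.12 log units; that floor lies within the scatter) by this estimate. For compound 4 the estimated value is 45000 nM with an expected range from 15000 nM to 120000 nM in this assay when it is measured.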

Compound 4, half-maximal inhibitory concentration: 19300 nM
For compound 4 the middle estimate is 2.3-fold (0.37 log units) above the measured one; low and high end bracket the measured number.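

This saturated ring carbon, next to the ring oxygen, now gives a readable result in this assay, where the earlier step between two groups there could not be read: the change is an at least 3.1-fold lower number from compound 2 to compound 4 (0.49 log units; beyond the scatter), and measured against methoxycarbonyl it is an at least 3.1-fold lower number from compound 1 to compound 4 (0.49 log units; beyond the scatter). Until now only a change on an aromatic carbon had moved the number, and this shows that a change on the saturated ring carbon, bringing in an aromatic ring, can do so too. Both sizes are floors and not full sizes, since each starting compound is held at a limit: the limit of > 60000 nM in this assay, at which 2 of the 4 values shown sit.

The compounds shown do not tell whether the ring nitrogen of pyridin-4-yl counts or the aromatic ring alone, which a phenyl group at this carbon would separate, nor how a longer chain or an amine there would behave. They also leave open whether the methyl group of compound 3 and the pyridin-4-yl group of compound 4 would add up in one compound.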